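A few compounds are considered here, and "the series" means these few. Any claim that something is new, unique, unknown or untested is made for them only; others in the source may bear on it.

Three compounds have so far been measured in a functional assay on T-24 cells (Homo sapiens) for antiproliferative activity, read by MTT assay, with a stated time of 48 h; on this read-out higher numbers stand for weaker inhibition and lower numbers for stronger inhibition:

Compound 1 `O=C(Nc1cccc(CNc2nccnc2Cl)c1)Nc1ccccc1Cl` gives 6680 nM.
Compound 2 `O=C(Nc1cccc(CNc2nccnc2Cl)c1)Nc1ccccc1F` gives 7450 nM.
Compound 3 `O=C(Nc1cccc(CNc2nccnc2Cl)c1)Nc1ccc(Cl)cc1Br` gives 6650 nM.

Compound 3 has the lowest of the three numbers, yet its separations from its neighbours are small: a 1.0-fold lower number from compound 1 to compound 3 (0.00 log units; within the scatter) and a 1.1-fold lower number from compound 2 to compound 3 (0.05 log units; within the scatter) both lie within the scatter, so the three compounds cannot be told apart on these results.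

Compound 4 `O=C(Nc1ccc(Cl)cc1)Nc1cccc(CNc2nccnc2Cl)c1` is the next step from compound 3, and the structural change is hydrogen in place of bromo on an aromatic carbon. Put another way, the ring on the urea nitrogen goes from 2-bromo-4-chlorophenyl to 4-chlorophenyl.

All three measured steps concern halogen changes on that same ring, and none moved the number: a 1.1-fold higher number from compound 1 to compound 2 (0.05 log units; within the scatter) exchanged one halogen for another, while a 1.0-fold lower number from compound 1 to compound 3 (0.00 log units; within the scatter) and a 1.1-fold lower number from compound 2 to compound 3 (0.05 log units; within the scatter) added a bromo alongside a chloro. Removing the bromo again is therefore expected to give a 1.1-fold higher number from compound 3 to compound 4 (0.02 log units; within the scatter), with no shift beyond the scatter in either direction. For compound 4 the expected value is 7000 nM, estimated to fall between 3500 nM and 14000 nM.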

Compound 4, half-maximal inhibitory concentration: 5470 nM
The estimate for compound 4 lay 1.3-fold (0.11 log units) above the measured number; measured number inside the range.
By their numbers in this assay, from the lowest: compounds 4, 3, 1 and 2 (each within the scatter of the next).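

Among the compounds shown here, compound 4 is the first here with hydrogen rather than a halogen at this position, ortho to a large group, and in this assay that change gives no separation (a 1.2-fold lower number from compound 3 to compound 4 (0.08 log units; within the scatter)). The 4-chlorophenyl ring of compound 4 also stays within the scatter of the rings with a single halogen at that position, both 2-fluorophenyl (a 1.4-fold lower number from compound 2 to compound 4 (0.13 log units; within the scatter)) and 2-chlorophenyl (a 1.2-fold lower number from compound 1 to compound 4 (0.09 log units; within the scatter)), so neither bromo nor any other halogen at this position is needed to keep the number in this range. No measurement shown speaks to why these compounds read alike.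

Every ring shown carries only halogens and hydrogen, so the effect of a methoxy, an amine or a carboxylic acid at this position stays open. An unsubstituted phenyl ring is also absent, so whether the 4-chloro group matters cannot be judged.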